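Two More Fluorines on the Fluorophenyl Group of Compound 1

A few compounds are considered here, and "the series" means these few. Any claim that something is new, unique, unknown or untested is made for them only; others in the source may bear on it.

Compound 1 `Cc1cc(Nc2nc(NCc3ccc(F)cc3)nc3ccccc23)n[nH]1` is the reference point. Within the data shown here, in an assay for inhibition of high affinity nerve growth factor receptor (Homo sapiens), read by HTRF, with a stated time of 30 min, in the presence of a further agent that is not named here (a lower number here means a stronger inhibitor, a higher number a weaker inhibitor), compound 1 gives 20 nM, the lowest of the three numbers measured so far, with compound 3 nearest and compound 2 furthest away. In this assay compound 2 `Cc1cc(Nc2nc(NCc3ccc(Cl)cc3)nc3ccccc23)n[nH]1` gives 380 nM, and compound 3 `Cc1cc(Nc2nc(NCc3ccc(C#N)cc3)nc3ccccc23)n[nH]1` gives 83 nM. The measured steps all replace the single fluorine with something else and all raise the number: a 19-fold higher number from compound 1 to compound 2 (1.28 log units; beyond the scatter), and a 4.2-fold higher number from compound 1 to compound 3 (0.62 log units; beyond the scatter); between those two, a 4.6-fold lower number from compound 2 to compound 3 (0.66 log units; beyond the scatter).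

Compound 4 `Cc1cc(Nc2nc(NCc3cc(F)c(F)c(F)c3)nc3ccccc23)n[nH]1` keeps that fluorine and adds two more: 3,4,5-trifluorophenyl in place of 4-fluorophenyl on a saturated chain carbon bound to a nitrogen on an aromatic ring. Among the measured compounds shown here, no measured pair shows what extra fluorines do, so the steps from compound 1 bear on it only loosely: every change so far at this ring gave a weaker inhibitor, and the single fluorine of compound 1 has been hard to improve on. For compound 4 a modest rise in the number is therefore expected, a 3.0-fold higher number from compound 1 to compound 4 (0.48 log units; beyond the scatter). Compound 4 is estimated at 60 nM, with a range from 15 nM to 250 nM.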

Compound 4, half-maximal inhibitory concentration: 870 nM
Beside the measured number, compound 4's estimate is 15-fold (1.16 log units) below it; the measured number lies above the stated range.
By their numbers in this assay, from the lowest: compound 1; then compound 3; then compound 2; then compound 4.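

In this assay, adding two fluorines while keeping the original one costs more than any single replacement seen so far at this ring: a 44-fold higher number from compound 1 to compound 4 (1.64 log units; beyond the scatter). The 3,4,5-trifluorophenyl group also falls behind both other replacements, with a 10-fold higher number from compound 3 to compound 4 (1.02 log units; beyond the scatter) and a 2.3-fold higher number from compound 2 to compound 4 (0.36 log units; beyond the scatter), so it gives the highest number of the four compounds, and keeping the 4-fluoro substituent of compound 1 does not by itself hold the number low. Nothing available explains why this change weakens inhibition so strongly.

The compounds shown leave open whether one added fluorine would already bring much of this loss, as a difluorophenyl group could show. They also leave open how a methoxy group or an amine on this ring would compare with the 4-fluorophenyl group of compound 1.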